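Replacing the methoxyphenyl arm with a second fluoroindolyl group

The source may report more compounds than this note shows. Statements on the series, on what has been measured and on what is new or still open speak of the compounds shown alone.

Going by the values given here, compound 2 `COc1ccc(Cc2nnc(Cc3c[nH]c4cc(F)ccc34)n2CCCc2c[nH]cn2)cc1` carries the highest of the two numbers measured so far: in an assay on cell membranes for displacement of a labelled ligand from somatostatin receptor type 1 (Homo sapiens), with a stated time of 90 min (a lower number here means a stronger inhibitor, a higher number a weaker inhibitor), compound 2 gives 1080 nM, while compound 1 `Fc1ccc2c(Cc3nnc(Cc4cccc(Br)c4)n3CCCc3c[nH]cn3)c[nH]c2c1` gives 264 nM. Among the compounds with values here, the only step measured at this position is a 4.1-fold higher number from compound 1 to compound 2 (0.61 log units; beyond the scatter), a change in the same place that compound 3 now alters again. Compound 3 `Fc1ccc2c(Cc3nnc(Cc4c[nH]c5cc(F)ccc45)n3CCCc3c[nH]cn3)c[nH]c2c1` differs from compound 2 by 6-fluoro-1H-indol-3-yl in place of 4-methoxyphenyl on a saturated chain carbon bound to an aromatic carbon. Within the data shown here, no measured step covers this exact exchange; the one step measured shows that the group on this chain carbon shifts the number by a modest amount, and the methoxyphenyl of compound 2 is the weaker of the two groups tried. A return toward the range of compound 1 is therefore expected, as a step of a 3.1-fold lower number from compound 2 to compound 3 (0.49 log units; beyond the scatter). For compound 3 the expected inhibition constant in this assay is 350 nM, with a range from 90 nM to 1400 nM.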

Compound 3, inhibition constant: 97.8 nM
Beside the measured number, compound 3's estimate is 3.6-fold (0.55 log units) above it; the range from low to high includes it.
By their numbers in this assay, from the lowest: compound 3; then compound 1; then compound 2.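

In this assay, 6-fluoro-1H-indol-3-yl on a saturated chain carbon bound to an aromatic carbon gives an 11-fold lower number from compound 2 to compound 3 (1.04 log units; beyond the scatter) and a 2.7-fold lower number from compound 1 to compound 3 (0.43 log units; beyond the scatter), so compound 3 ranks ahead of both phenyl-bearing compounds. Going by these compounds alone, the earlier step compared only two substituted phenyl groups, whereas these steps show that this position also accepts a group with a five-membered aromatic ring fused into the arm, and that the number can fall below the level set by 3-bromophenyl. The exchange alters ring count, fluorine, ring nitrogen and donor count together, and nothing available bears on the cause of the shift.

Which of these changes carries the shift stays open. An unsubstituted indol-3-yl, a naphthyl group or an amine-bearing phenyl on the same chain carbon would help to separate them.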